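The source may hold more compounds than are shown below. What is called first, only, known or untested is meant among the compounds shown, and "the series" means these compounds.

Measured so far:
compound 1, `O=C1OCCN1c1cc(C(F)(F)F)ccc1[C@H]1CCOc2cc(S(=O)(=O)Nc3nccs3)ccc21`: 2.1
compound 2, `O=S(=O)(Nc1ccncn1)c1ccc2c(c1)OCC[C@@H]2c1ccc(C(F)(F)F)cc1-c1ccc(F)cn1`: 3

Both compounds were measured in a physicochemical assay for lipophilicity; a higher number here means a more lipophilic compound, a lower number a more polar compound. Compound 1 gives the lower of the two numbers; compound 2 stands higher, and the gap between them is beyond the usual scatter. Compound 2 differs from compound 1 in more than one place, so no single step can be read off from that pair.

The step of interest runs from compound 1 to compound 3, `O=S(=O)(Nc1nccs1)c1ccc2c(c1)OCC[C@@H]2c1ccc(C(F)(F)F)cc1-c1nccs1`, which has not yet been measured in this assay. The change is 1,3-thiazol-2-yl in place of 2-oxo-1,3-oxazolidin-3-yl on an aromatic carbon. A non-aromatic ring carrying a carbonyl gives way to an aromatic one of similar size, with the same count of hydrogen-bond acceptors and no donors in either.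

Within the data shown here, no measured pair shows exactly this change, so its size has to be estimated. Compound 2, which carries an aromatic ring in place of the oxazolidinone and gives 3, suggests that compounds of this family can sit well above compound 1. The step from compound 1 to compound 3 is expected to be a rise beyond the scatter, a number 1.20 log units higher from compound 1 to compound 3 (beyond the scatter). Compound 3 is expected to come out near 3.3, within a range from 2.7 to 3.9.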

Compound 3, distribution coefficient: 3.3
The estimate for compound 3 equals the measured number at the digits printed, within the range that was stated.
By their numbers in this assay, from the lowest: compound 1; then compounds 2 and 3 (each within the scatter of the next).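

Read in this assay, putting 1,3-thiazol-2-yl in place of 2-oxo-1,3-oxazolidin-3-yl on an aromatic carbon, ortho to a large group and meta to a trifluoromethyl group, gives a number 1.20 log units higher from compound 1 to compound 3 (beyond the scatter). This is the first pair shown that differs in one place only, so the effect of this change at this position can now be read on its own, free of any other difference between the compounds. The leaving and entering groups have the same counts of hydrogen-bond donors and acceptors, so those counts do not track this large step, and no measurement is available that explains its size.

From the compounds shown here alone, one pair gives a single step for a single swap, so it remains open how a small amine, a carboxylic acid, a methoxy group or a longer alkyl chain would read at this same position. Going by these compounds, it also remains open whether the same swap would give a step of similar size in compounds that otherwise match compound 2, where the rest of the molecule differs from compound 1.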